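This account rests on a few compounds, and the source may have more. Where it says the series, first, only, none or still open, it means among the compounds named here.

Among the measured compounds shown here, compound 3 `C=CCn1c(=O)/c(=C\c2ccccc2C(F)(F)F)[nH]c(=O)/c1=C\c1ccccc1OC` gives 4400 nM in a functional assay on MOLT-4 cells (Homo sapiens) for cytotoxicity, read by CCK-8 assay, with a stated time of 72 h (a higher number here means a weaker inhibitor, a lower number a stronger inhibitor), the lowest of the three numbers measured so far. Compound 2 `C=CCn1c(=O)/c(=C\c2cccc(Br)c2)[nH]c(=O)/c1=C\c1ccccc1OC` gives 5000 nM in this assay, and the pair sits within the scatter, as a 1.1-fold lower number from compound 2 to compound 3 (0.06 log units; within the scatter) shows. Compound 1 `C=CCn1c(=O)/c(=C\c2cc(Br)ccc2F)[nH]c(=O)/c1=C\c1ccccc1OC` gives 12900 nM in this assay, and a 2.9-fold lower number from compound 1 to compound 3 (0.47 log units; beyond the scatter) is a modest step beyond the scatter; likewise a 2.6-fold lower number from compound 1 to compound 2 (0.41 log units; beyond the scatter) is a modest step beyond the scatter.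

Compound 4 `C=CCn1c(=O)/c(=C\c2ccc(F)c(Br)c2)[nH]c(=O)/c1=C\c1ccccc1OC` differs from compound 3 in one place: 3-bromo-4-fluorophenyl in place of 2-(trifluoromethyl)phenyl on a double-bonded chain carbon bound to an aromatic carbon. For the measured compounds named here, two measured steps bear on this. The exchange of the 2-(trifluoromethyl)phenyl for a bromophenyl, seen from compound 3 to compound 2, moved the number by no more than the scatter. The loss of a fluoro from a ring that also carried bromo, seen from compound 1 to compound 2, lowered the number modestly, so a ring that carries both bromo and fluoro, as in compound 4, might be expected to run somewhat higher than compound 2. Going by the values given here, the arrangement in compound 4 has no direct precedent among the measured compounds.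

Compound 4 is therefore expected to give a number near or somewhat above compound 3, with a 1.6-fold higher number from compound 3 to compound 4 (0.20 log units; within the scatter) as the estimated step, so the estimate for compound 4 is 7000 nM, within the range 3000 nM to 17000 nM.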

Compound 4, half-maximal inhibitory concentration: "not active" (no number reported)
Nothing numeric was reported for compound 4; the estimate stays without a comparison.
By their numbers in this assay, from the lowest: compounds 3 and 2 (each within the scatter of the next); then compound 1.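

Among the compounds shown here, compound 4 is reported as "not active" in this assay with no number, so no step from compound 3 to compound 4, or to any other compound, can be read. The compounds shown leave open how far 3-bromo-4-fluorophenyl separates from 2-(trifluoromethyl)phenyl in this read-out. Nothing shown here accounts for the result.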